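A few compounds are considered here, and "the series" means these few. Any claim that something is new, unique, unknown or untested is made for them only; others in the source may bear on it.

In an ADME assay for pharmacokinetics (on this read-out higher numbers stand for a longer-lived compound and lower numbers for a shorter-lived compound), compound 1 `N=C(N)SCCOc1oc(=O)c2cc(NC(=O)CCc3ccccc3)ccc2c1Cl` gives 0.65 h. Within the data shown here, the only other measured compound, compound 2 `C[C@H](NC(=O)Nc1ccc2c(Cl)c(OCCSC(=N)N)oc(=O)c2c1)c1ccccc1`, gives 0.933 h, so these two numbers lie within the scatter of each other. Compound 3 `N=C(N)SCCCOc1oc(=O)c2cc(NC(=O)CCc3ccccc3)ccc2c1Cl` keeps the shared core and the phenethyl on the carbonyl carbon of compound 1, and differs from it in one place: a group of 5 heavy atoms (2 carbon, 2 nitrogen, 1 sulfur; no ring) in place of a group of 4 heavy atoms (1 carbon, 2 nitrogen, 1 sulfur; no ring), on a saturated chain carbon, two bonds along the chain from an oxygen on an aromatic ring. Among the measured compounds shown here, no measured step touches this part of the chain. For the measured compounds named here, the one available step, a 1.4-fold higher number from compound 1 to compound 2 (0.16 log units; within the scatter), replaces phenethyl with (1-phenylethyl)amino on a carbonyl carbon, which is a different place in the molecule, so it offers only weak guidance. With no direct evidence of a shift, no change beyond the scatter is expected. The expected size of the step is no change at the digits printed from compound 1 to compound 3 (within the scatter). Compound 3 is estimated at 0.65 h, with an expected range from 0.33 h to 1.3 h.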

Compound 3, half-life: 1.1 h
Compound 3: middle estimate off by 1.7-fold (0.23 log units), on the low side; measured number inside the range.
By their numbers in this assay, from the lowest: compounds 1, 2 and 3 (each within the scatter of the next).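

In this assay, among these compounds, the group of 5 heavy atoms in place of the group of 4 heavy atoms gives a 1.7-fold higher number from compound 1 to compound 3 (0.23 log units; within the scatter) and so provides the first reading at this place, on a saturated chain carbon, two bonds along the chain from an oxygen on an aromatic ring. The step lies within the scatter, so this change cannot be told apart from no change on this read-out, and the chain here tolerates the swap without a clear shift in either direction. No supporting measurement is available to explain the result.

A longer chain at this place, or an amine or a carboxylic acid in place of the group, remains untested among the compounds shown, so the limits of this tolerance in this assay stay unknown. As far as these compounds go, it is also open whether the same change would give a similar step with (1-phenylethyl)amino on the carbonyl carbon.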